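The source may hold more compounds than are shown below. What is called first, only, known or untested is meant among the compounds shown, and "the series" means these compounds.

Working notes on the series. In a functional assay on HeLa cells (Homo sapiens) for antiproliferative activity, read by cell counting, with a stated time of 3 days (a higher number here means a weaker inhibitor, a lower number a stronger inhibitor), compound 1 `CC(Nc1ccccc1Oc1ccc(Cl)cc1)=C1C(=O)CC(c2ccccc2)CC1=O` gives 500 nM, compound 2 `COc1ccc(Oc2ccccc2NC(C)=C2C(=O)CC(c3ccccc3)CC2=O)cc1OC` gives 54 nM and compound 3 `COc1cc(Oc2ccccc2NC(C)=C2C(=O)CC(c3ccccc3)CC2=O)ccc1N` gives 33 nM. Compound 3 thus stands at the low end of the three numbers, with a 1.6-fold lower number from compound 2 to compound 3 (0.21 log units; within the scatter) and a 15-fold lower number from compound 1 to compound 3 (1.18 log units; beyond the scatter).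

Compound 4 `CC(Nc1ccccc1Oc1ccc(C(C)O)cc1)=C1C(=O)CC(c2ccccc2)CC1=O` is still unmeasured. The change is 4-(1-hydroxyethyl)phenyl in place of 4-amino-3-methoxyphenyl on an oxygen on an aromatic ring, with 4-(1-hydroxyethyl)phenyl in place of 4-amino-3-methoxyphenyl on an oxygen on an aromatic ring.

The nearest evidence is the change of group at this same place, which gave the large step above and a 9.3-fold lower number from compound 1 to compound 2 (0.97 log units; beyond the scatter). Both measured gains came with methoxy-bearing groups, and the entering group has no methoxy, so part of the gain is expected to be lost. In this assay a modest move to a higher number is expected, an estimated 4.5-fold higher number from compound 3 to compound 4 (0.66 log units; beyond the scatter). For compound 4 the estimate is 150 nM, with an expected range of 40 nM to 600 nM.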

Compound 4, half-maximal inhibitory concentration: 75 nM
For compound 4 the middle estimate is 2.0-fold (0.30 log units) above the measured one, within the range that was stated.
By their numbers in this assay, from the lowest: compounds 3, 2 and 4 (each within the scatter of the next, the first and the last beyond it); then compound 1.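

In this assay, 1-hydroxyethyl in place of chloro on an aromatic carbon also brings a gain (a 6.7-fold lower number from compound 1 to compound 4 (0.82 log units; beyond the scatter)), so at this place a gain does not depend on a methoxy group. The entering 4-(1-hydroxyethyl)phenyl reads within the scatter of 3,4-dimethoxyphenyl (a 1.4-fold higher number from compound 2 to compound 4 (0.14 log units; within the scatter)), while 4-amino-3-methoxyphenyl retains a modest edge over it (a 2.3-fold higher number from compound 3 to compound 4 (0.36 log units; beyond the scatter)). No measurement at hand accounts for these differences.

From the compounds shown here alone, whether the hydroxy of the 1-hydroxyethyl group is needed remains open. An ethyl group, an acetyl group or a carboxylic acid at the same ring position would test this.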